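Urea series: trifluoromethyl added to the fluorinated ring

The compounds below may be only part of what the source reports. "The series", "measured", "known", "first", "only" and "open" are said of these compounds alone.

Measured so far:
compound 1, `CC(C)c1ccccc1NC(=O)N[C@@H](C)c1ccccc1`, 93%
compound 2, `C[C@H](NC(=O)Nc1ccccc1F)c1ccccc1`, 65%

In an ADME assay on the whole organism with Oryza sativa as the target, tested at 10 uM (on this read-out lower numbers stand for a stronger effect and higher numbers for a weaker effect at the one concentration tested), compound 1 gives 93%. Among the compounds with values here, compound 2 gives 65% in this assay, the lower of the two numbers; the only measured step, a number 28 percentage points lower from compound 1 to compound 2 (beyond the scatter), lies beyond the scatter. Compound 3, `C[C@H](NC(=O)Nc1cccc(C(F)(F)F)c1F)c1ccccc1`, is not yet measured. It differs from compound 2 as follows: trifluoromethyl in place of hydrogen on an aromatic carbon. Within the data shown here, no measured step involves a trifluoromethyl group, and the one step seen changes a different group, so no direct guide exists for this change; the scatter of the read-out is the main reference. A step of about a number 7 percentage points lower from compound 2 to compound 3 (within the scatter) is expected, small against the scatter and close to no change, with the direction uncertain. Compound 3 is therefore expected to give 58% in this assay, within a range of 38% to 82%.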

Compound 3, a percentage reported as activity, at one concentration (the size of the read-out at that concentration, not a potency): 100%
Compound 3: middle estimate off by 42 percentage points, on the low side; measured number outside the range, above it.
By their numbers in this assay, from the lowest: compound 2; then compounds 1 and 3 (each within the scatter of the next).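

In this assay trifluoromethyl in place of hydrogen, ortho to a fluoro group, gives a number 35 percentage points higher from compound 2 to compound 3 (beyond the scatter) and so does not retain the low number of compound 2. This aromatic carbon is therefore sensitive to substitution in this series, a point that the earlier step, which changed a different place on the ring, could not show. No measurement in hand bears on what lies behind this step.

On these data alone, it remains open whether a smaller group on the same aromatic carbon, such as methyl or a chlorine atom, or a polar one such as an amine, would keep the number near that of compound 2. The size of the step may also depend on the fluoro group, and the compounds shown do not test trifluoromethyl on this ring without it.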